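Methoxy to phenoxy on compound 2: cytotoxicity working notes

The compounds below may be only part of what the source reports. "The series", "measured", "known", "first", "only" and "open" are said of these compounds alone.

In an ADME assay on Vero cells (Chlorocebus sabaeus) for cytotoxicity (on this read-out higher numbers stand for lower toxicity in this test and lower numbers for higher toxicity in this test), compound 2 (`COc1ccccc1-c1nc2ccncc2s1`) gives > 50000 nM as a limit of the assay and not a number. Compound 1 (`c1ccc(Oc2ncccc2-c2nn3cnnc3s2)cc1`) also carries phenoxy and gives > 50000 nM as a limit too. Within the data shown here, both thus stand at the limit of > 50000 nM in this assay, at which 2 of the 2 values shown sit, and no numeric step is available. Compound 3 (`c1ccc(Oc2ccccc2-c2nc3ccncc3s2)cc1`) has phenyl in place of methyl on an oxygen on an aromatic ring. The expected change in this assay is a number no higher from compound 2 to compound 3 (the limit leaves the size open) and so none beyond the scatter. Compound 3 is estimated at 50000 nM with an expected range from 20000 nM to 50000 nM on this read-out.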

Compound 3, half-maximal cytotoxic concentration: > 50000 nM
Compound 3: only a limit was reported (the forecaster's own chance of this, stated with the estimate: 75%); the middle value sits exactly at the limit.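

Compound 2 and compound 3 both stand at a limit in this assay and no step can be read between them: the limit of > 50000 nM in this assay, at which 3 of the 3 values shown sit. The compounds shown leave open whether methoxy to phenoxy changes cytotoxicity at all, since none gives a number.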